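The source may report more compounds than this note shows. Statements on the series, on what has been measured and on what is new or still open speak of the compounds shown alone.

Compound 1 `C#CCNC1CCc2c(OCCCCN3CCN(c4cccc5c4ccn5Cc4cccc(Cl)c4)CC3)cccc21` and compound 2 `C#CCNC1CCc2c(OCCCCCN3CCN(c4cccc5c4ccn5Cc4cccc(Cl)c4)CC3)cccc21` share the same substituent pattern on different cores; the difference between the two cores is not broken down here. In an assay on HEK293 cells for displacement of a labelled ligand from 5-hydroxytryptamine receptor 6 (Homo sapiens), read by scintillation counting, with a stated time of 1 h (a higher number here means a weaker inhibitor, a lower number a stronger inhibitor), compound 1 gives 113 nM, and compound 2 gives 223 nM, a gap that stays within the usual scatter. Compound 3 `C#CCNC1CCc2c(OCCCCN3CCN(c4cccc5c4ccn5S(=O)(=O)c4ccccc4)CC3)cccc21` carries phenylsulfonyl in place of 3-chlorobenzyl on an aromatic nitrogen; in this assay compound 3 gives 50 nM, so the step of a 2.3-fold lower number from compound 1 to compound 3 (0.35 log units; beyond the scatter) is modest but beyond the scatter. Compound 4 `C#CCNC1CCc2c(OCCCCCN3CCN(c4cccc5c4ccn5S(=O)(=O)c4ccccc4)CC3)cccc21` carries the same change on the core of compound 2, namely (phenylsulfonyl in place of 3-chlorobenzyl on an aromatic nitrogen). For compound 4 the expected step is a 2.3-fold lower number from compound 2 to compound 4 (0.36 log units; beyond the scatter), placed beside the earlier one because a 2.3-fold lower number from compound 1 to compound 3 (0.35 log units; beyond the scatter) was seen with the same change. Compound 4 is therefore estimated at 97 nM, with a range from 45 nM to 220 nM.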

Compound 4, inhibition constant: 51 nM
The estimate for compound 4 lay 1.9-fold (0.28 log units) above the measured number; low and high end bracket the measured number.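

In this assay phenylsulfonyl in place of 3-chlorobenzyl on an aromatic nitrogen again gives a lower number, with a 4.4-fold lower number from compound 2 to compound 4 (0.64 log units; beyond the scatter). The direction is the same on both cores, and the sizes of the two steps cannot be told apart: the same change on two cores in this assay, a 2.3-fold lower number (0.35 log units; beyond the scatter) from compound 1 to compound 3 and a 4.4-fold lower number (0.64 log units; beyond the scatter) from compound 2 to compound 4, 1.9-fold (0.29 log units) apart, within the scatter of two such steps. This supports carrying the change between these two cores only; two pairs do not establish that it carries to other cores, and they do not show which part of the change accounts for the step.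

Still open, from the compounds shown here alone, is whether a similar step appears with other groups on that aromatic nitrogen, such as benzoyl or methylsulfonyl. An unsubstituted benzyl group would show what the chlorine contributes.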